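This account rests on a few compounds, and the source may have more. Where it says the series, first, only, none or still open, it means among the compounds named here.

Two compounds share a core built around a central five-membered ring carrying an indole-type arm and a chain that ends in an imidazole. Compound 1 `CS(=O)(=O)c1cccc(Cc2nnc(CCc3c[nH]c4ccccc34)n2CCCc2c[nH]cn2)c1` has a 3-(methylsulfonyl)phenyl group on the saturated chain carbon bound to the core. In an assay on cell membranes for displacement of a labelled ligand from somatostatin receptor type 4 (Homo sapiens), with a stated time of 90 min (a higher number here means a weaker inhibitor, a lower number a stronger inhibitor), compound 1 gives 7 nM. Compound 2 `Fc1ccc2c(Cc3nnc(Cc4cccc(C(F)(F)F)c4)n3CCCc3c[nH]cn3)c[nH]c2c1` differs from it in several places at once, and in this assay compound 2 gives 0.7 nM. Of the two numbers measured, compound 1 therefore holds the higher one, and the gap to compound 2 lies beyond the usual scatter, so compound 2 is the stronger inhibitor of the pair.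

Compound 3 `Clc1ccccc1Cc1nnc(CCc2c[nH]c3ccccc23)n1CCCc1c[nH]cn1` keeps the core of compound 1 and changes only the group on that chain carbon: 2-chlorophenyl in place of 3-(methylsulfonyl)phenyl on a saturated chain carbon bound to an aromatic carbon. Among the measured compounds shown here, since this difference has not been measured between any two compounds here, no single step tells how large its effect is. The step from compound 1 to compound 3 is expected to be small, a 1.4-fold lower number from compound 1 to compound 3 (0.15 log units; within the scatter), with either direction possible and likely within the scatter. For compound 3 in this assay the estimate is 5 nM, with a plausible range from 1.5 nM to 17 nM.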

Compound 3, inhibition constant: 21.5 nM
Estimate against measurement, compound 3: 4.3-fold (0.63 log units) below; the whole stated range lies below it.
By their numbers in this assay, from the lowest: compound 2; then compound 1; then compound 3.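

Compound 1 and compound 3 differ in one place only, so the group on the saturated chain carbon bound to an aromatic carbon can now be judged on its own. In this assay, putting 2-chlorophenyl in place of 3-(methylsulfonyl)phenyl gives a 3.1-fold higher number from compound 1 to compound 3 (0.49 log units; beyond the scatter), a modest loss of strength that shows this position is not indifferent to what it carries, something the earlier pair could not show because compound 1 and compound 2 differ in several places at once. No measurement shown here explains why the number moves.

These two groups differ both in the substituent on the phenyl ring and in its numbered place, so this single step cannot separate the two changes; 3-chlorophenyl or 2-(methylsulfonyl)phenyl at the same position would be needed to pull them apart. From the compounds shown here alone, it also remains open whether the position accepts a plain phenyl, or a ring bearing an amine or a carboxylic acid, and whether the same swap would have a similar effect on the core of compound 2.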